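The compounds below may be only part of what the source reports. "The series", "measured", "known", "first", "only" and "open" are said of these compounds alone.

Working notes on the coumarin-ketone series, measured in an assay on cells for inhibition of Amine oxidase [flavin-containing] A (Homo sapiens), read by fluorescence, spectrophotometry and Amplex Red, with stated times of 60 min and 30 min; a higher number here means a weaker inhibitor, a lower number a stronger inhibitor.

Compound 1 `CN(C)CCC(=O)c1cc2ccc(O)cc2oc1=O` carries a free hydroxyl on the aromatic ring and a dimethylamino group on the saturated chain; in this assay compound 1 gives 110000 nM. Compound 2 `COc1ccc2cc(C(=O)CCN(C)C)c(=O)oc2c1` differs only in the methyl on that oxygen, and in this assay compound 2 gives 7630 nM. Among the compounds with values here, the step of a 14-fold lower number from compound 1 to compound 2 (1.16 log units; beyond the scatter) is the only measured step so far. Within the data shown here, on the two numbers in hand, compound 2 stands at the lower end, with compound 1 as its sole neighbour.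

Compound 3 `COc1ccc2cc(C(=O)CCN3CCCC3)c(=O)oc2c1` is the next entry, not yet measured. Relative to compound 2 the change is pyrrolidin-1-yl in place of dimethylamino on a saturated chain carbon, two bonds along the chain from a carbonyl carbon. Among the measured compounds shown here, no measured step touches the amine end of the chain: the single step known, from compound 1 to compound 2, concerns the oxygen on the aromatic ring and gives no guide to an exchange at the nitrogen. With nothing to lean on, the expectation for compound 3 in this assay is a step of about a 1.3-fold lower number from compound 2 to compound 3 (0.10 log units; within the scatter), not clearly beyond the scatter in either direction. The estimate for compound 3 is therefore 6000 nM, within the range 2000 nM to 18000 nM.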

Compound 3, half-maximal inhibitory concentration: 53100 nM
Estimate against measurement, compound 3: 8.9-fold (0.95 log units) below; the whole stated range lies below it.
By their numbers in this assay, from the lowest: compound 2; then compound 3; then compound 1.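

The amine end of the chain is not a silent position in this assay: a 7.0-fold higher number from compound 2 to compound 3 (0.84 log units; beyond the scatter) is a step beyond the scatter, so the number responds to an exchange at the nitrogen as well as to the methyl on the aromatic oxygen seen in a 14-fold lower number from compound 1 to compound 2 (1.16 log units; beyond the scatter). In this single pair, pyrrolidin-1-yl, with 5 heavy atoms and one five-membered non-aromatic ring, goes with the weaker inhibitor, while dimethylamino, with 3 heavy atoms and no ring, goes with the stronger one; the listed counts of hydrogen-bond donors and acceptors and the net charge are the same for both groups. Nothing measured on these compounds bears on why the exchange moves the number in this direction.

Going by these compounds, whether the ring itself or only the added carbons go with the weaker inhibition stays open, and a diethylamino, piperidin-1-yl or morpholin-4-yl group on the same chain carbon would help separate the two. Also open, on these data alone, is whether the same exchange would give a similar step with the free hydroxyl of compound 1 or with a longer chain between the carbonyl and the nitrogen.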